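From 1H-indol-6-yl to thiophen-2-yl on a shared core

This account rests on a few compounds, and the source may have more. Where it says the series, first, only, none or still open, it means among the compounds named here.

In a functional assay on A549 cells (Homo sapiens) for antiproliferative activity, read by MTT assay, with a stated time of 48 h (on this read-out lower numbers stand for stronger inhibition and higher numbers for weaker inhibition), compound 1 `COc1cc(-c2cccc3nc(-c4ccc(Br)cc4)oc23)cc(OC)c1OC` gives > 25000 nM as a limit of the assay and not as a number. Among the compounds with values here, compound 2 `COc1cc(-c2cccc3nc(-c4ccc5cc[nH]c5c4)oc23)cc(OC)c1OC` gives 55 nM and holds the only actual number so far. Compound 3 `COc1cc(-c2cccc3nc(-c4cccs4)oc23)cc(OC)c1OC` has not yet been measured. The change that leads to it from compound 2 is thiophen-2-yl in place of 1H-indol-6-yl on an aromatic carbon and it sits on an aromatic carbon of the five-membered aromatic ring with 1 nitrogen and 1 oxygen. Within the data shown here, one measured step bears on this place: an at least 450-fold lower number from compound 1 to compound 2 (2.65 log units; beyond the scatter) is large and lies beyond the scatter, and it brought in the same 1H-indol-6-yl that compound 3 gives up. With that single step as a guide, a change of group here can matter greatly in this assay and removing 1H-indol-6-yl is expected to cost activity. The expected step is a 27-fold higher number from compound 2 to compound 3 (1.44 log units; beyond the scatter) in the direction of weaker inhibition and beyond the scatter, though probably smaller than the one measured. Compound 3 is estimated at 1500 nM with an expected range from 150 nM to 15000 nM in this read-out.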

Compound 3, half-maximal inhibitory concentration: 12500 nM
Estimate against measurement, compound 3: 8.3-fold (0.92 log units) below, within the range that was stated.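

Thiophen-2-yl on this aromatic carbon of the five-membered ring does not retain the activity of 1H-indol-6-yl: in this assay the change gives a 230-fold higher number from compound 2 to compound 3 (2.36 log units; beyond the scatter) and so adds a second large loss to the one already seen with 4-bromophenyl. Among the three groups shown at this place, only 1H-indol-6-yl gives strong inhibition, and the smaller five-membered thiophen-2-yl ring does not recover it, so the result with 4-bromophenyl was not a matter of that one group alone. Thiophen-2-yl and 4-bromophenyl cannot be put in order, since the step reads an at least 2.0-fold lower number from compound 1 to compound 3 (0.30 log units; that floor lies within the scatter) and its floor rests on a limit and not on a number: the limit of > 25000 nM in this assay, at which 1 of the 3 values shown sits.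

Thiophen-2-yl differs from 1H-indol-6-yl both in its ring count and in lacking a hydrogen-bond donor, so the compounds shown leave open which of these differences, if either, accounts for the step. They also leave open how a benzofuranyl group, with oxygen in place of the indole nitrogen, or a naphthyl group, with carbon there, would behave at this place.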